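Lengthening a terminal alkyne chain on a shared nucleoside core

The source may report more compounds than this note shows. Statements on the series, on what has been measured and on what is new or still open speak of the compounds shown alone.

Measured so far:
- compound 1, `CCCCCCCCc1cc2cn([C@H]3C[C@H](O)[C@@H](CO)O3)c(=O)nc2o1`: > 50000 nM
- compound 2, `C=CCCCc1cc2cn([C@H]3C[C@H](O)[C@@H](CO)O3)c(=O)nc2o1`: > 200000 nM
- compound 3, `C#CCCCCc1cc2cn([C@H]3C[C@H](O)[C@@H](CO)O3)c(=O)nc2o1`: > 200000 nM

In a functional assay on HEL cells (Homo sapiens) for cytotoxicity, read by microscopy (a higher number here means that more compound is tolerated, a lower number that less compound is tolerated), compound 1 reaches only a limit of the assay, > 50000 nM. Compound 2 likewise shows only a limit, > 200000 nM. Compound 3 also gives only a limit, > 200000 nM, so no number exists for it, only a floor. All three measured compounds sit at limits, two of them at the limit of > 200000 nM in this assay, at which 2 of the 3 values shown sit, and one at the limit of > 50000 nM in this assay, at which 1 of the 3 values shown sits, and the three steps among them, a step that the two limits leave unreadable from compound 1 to compound 2, a step that the two limits leave unreadable from compound 1 to compound 3 and a step that the two limits leave unreadable from compound 2 to compound 3, cannot be read in size or direction.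

The unmeasured compound 4, `C#CCCCCCCc1cc2cn([C@H]3C[C@H](O)[C@@H](CO)O3)c(=O)nc2o1`, differs from compound 3 by but-3-yn-1-yl in place of ethynyl on a saturated chain carbon, four bonds along the chain from an aromatic carbon.

Within the data shown here, none of the measured steps gives a readable size to carry over, so there is no basis for expecting a step beyond the scatter in this assay in either direction; the measured values only indicate that compounds tend to reach the assay limit. Compound 4 is therefore expected to give 200000 nM, within 50000 nM to 400000 nM, most likely again as a limit. This estimate corresponds to a number no higher from compound 3 to compound 4 (the limit leaves the size open), which is expected rather than known.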

Compound 4, minimum cytotoxic concentration: > 200000 nM
Compound 4: no number, only a limit; the forecaster's own chance of this, stated with the estimate: 80%; the middle value lies on the limit itself.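

In this assay, compound 4 gives only a limit, > 200000 nM, so its steps from compound 1, compound 2 and compound 3 cannot be read in size or direction. The compounds shown leave open how much of each compound the cells would tolerate before damage appears, and whether the chain makes any difference to that.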